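The compounds below may be only part of what the source reports. "The series", "measured", "known", "first", "only" and "open" are said of these compounds alone.

In a functional assay, read by fluorescence and spectrophotometry, with a stated time of 1 h (a lower number here means that less compound is needed, a higher number that more compound is needed for the effect), compound 3 `O=S(=O)(/C=C/c1ccc(O)c(O)c1)CCCCCCCCCO` gives 7500 nM and so stands within the scatter of the other two measured compounds. Compound 2 `CCCCCCCCCS(=O)(=O)/C=C/c1ccc(O)c(O)c1` gives 7700 nM and compound 1 `CCCCCCCCCCCS(=O)(=O)/C=C/c1ccc(O)c(O)c1` gives 11400 nM in the same read-out. The change leading to compound 4 `CCCCCCCCCCS(=O)(=O)/C=C/c1ccc(O)c(O)c1` is methyl in place of hydroxy on a saturated chain carbon, nine bonds along the chain from a sulfonyl sulfur. The measured steps at that same place are a 1.0-fold lower number from compound 2 to compound 3 (0.01 log units; within the scatter) and a 1.5-fold lower number from compound 1 to compound 3 (0.18 log units; within the scatter) and a 1.5-fold lower number from compound 1 to compound 2 (0.17 log units; within the scatter) and all of them lie within the scatter. No step beyond the scatter is therefore expected in this assay for this change, and the expected step is small (a 1.3-fold higher number from compound 3 to compound 4 (0.10 log units; within the scatter)). Compound 4 is estimated at 9500 nM within an expected range (5500 nM to 15000 nM).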

Compound 4, half-maximal effective concentration: 6800 nM
Compound 4: the middle estimate sits 1.4-fold (0.15 log units) above what was measured, and the stated range covers the measured number.
By their numbers in this assay, from the lowest: compounds 4, 3, 2 and 1 (each within the scatter of the next).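

In this assay, methyl at this chain carbon adds a further result within the scatter: there is a 1.1-fold lower number from compound 3 to compound 4 (0.04 log units; within the scatter), a 1.1-fold lower number from compound 2 to compound 4 (0.05 log units; within the scatter) and a 1.7-fold lower number from compound 1 to compound 4 (0.22 log units; within the scatter). Hydrogen, methyl, ethyl and hydroxy at this place therefore all give numbers within the scatter of one another, so exchanging hydroxy for methyl shows no measurable effect here. No available evidence bears on this result. The compounds shown leave open whether an amine or a carboxylic acid at this chain carbon, or a longer chain, would produce a step beyond the scatter.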